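The compounds below may be only part of what the source reports. "The series", "measured", "known", "first", "only" and "open" are said of these compounds alone.

Compound 1 `COc1ccc(N/C=C\C(=O)c2nc(-c3ccc(C(F)(F)F)cc3)n3ccccc23)cc1OC` stands at a limit in a functional assay on BT-474 cells (Homo sapiens) for cytotoxicity, read by MTT assay, with a stated time of 48 h; on this read-out higher numbers stand for weaker inhibition and lower numbers for stronger inhibition: in this assay compound 1 gives > 30000 nM, which is a limit of the assay and not a number. Compound 3 `COc1ccc(N/C=C\C(=O)c2nc(-c3ccc(F)cc3)n3ccccc23)cc1OC`, carrying fluoro in place of trifluoromethyl on an aromatic carbon, likewise gives > 30000 nM in this assay, again a limit. Within the data shown here, the only measured step, a step that the two limits leave unreadable from compound 1 to compound 3, therefore cannot be read, since the limit of > 30000 nM in this assay, at which 2 of the 3 values shown sit, covers both of its ends. Compound 2 `COc1ccc(N/C=C\C(=O)c2nc(-c3ccc(OC)cc3)n3ccccc23)cc1` differs from compound 1 in two places; in this assay compound 2 gives 15400 nM, a weak but measurable number.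

Compound 4 `O=C(/C=C\Nc1cnc2ccccc2c1)c1nc(-c2ccc(C(F)(F)F)cc2)n2ccccc12` has not been measured. It differs from compound 1 by quinolin-3-yl in place of 3,4-dimethoxyphenyl on an amine nitrogen. Among the measured compounds shown here, no measured step touches the amine nitrogen where this change sits, and the single step that exists, at another ring, is unreadable. Compound 1 itself offers only a limit. There is thus no anchor for a direction, and compound 4 is expected to remain in the same weak region, with a fair chance that this assay again reports only a limit. The step from compound 1 to compound 4 is estimated as an at least 1.2-fold lower number from compound 1 to compound 4 (0.07 log units; that floor lies within the scatter), no change beyond the scatter. Compound 4 is estimated at 25000 nM, with a range from 8000 nM to 60000 nM.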

Compound 4, half-maximal inhibitory concentration: > 30000 nM
Compound 4 gave a limit, no number (the forecaster's own chance of this, stated with the estimate: 55%); middle value at least 1.2-fold (0.07 log units) away from the limit.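

Among these compounds, compound 4, like compound 1, stands at a limit and not at a number, so the comparison between these two compounds yields no new readable step: the limit of > 30000 nM in this assay, at which 3 of the 4 values shown sit. The compounds shown leave open whether quinolin-3-yl or 3,4-dimethoxyphenyl on the amine nitrogen gives the lower number in this assay.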